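A few compounds are considered here, and "the series" means these few. Any claim that something is new, unique, unknown or untested is made for them only; others in the source may bear on it.

Measured compounds:
Compound 1: `CCC1=C(O)c2c(oc(-c3ccc(C(F)(F)F)cc3)cc2=O)C(CC)(CC)C1=O`, 10.4 uM
Compound 2: `CCC1=C(O)c2c(oc(-c3cccc(C)c3)cc2=O)C(CC)(CC)C1=O`, 3.69 uM

The two compounds share a common core and differ only in the aryl group attached to it. In a functional assay on KBVIN cells (Homo sapiens) for antiproliferative activity, read by sulforhodamine B assay, with a stated time of 3 days (a lower number here means that less compound is needed, a higher number that more compound is needed for the effect), compound 1 gives 10.4 uM, while compound 2 gives 3.69 uM. Compound 2 thus stands at the lowest of the two numbers recorded, and the gap to compound 1 lies beyond the usual scatter of this assay, so compound 2 is the more potent of the pair on these numbers.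

Compound 3, `CCC1=C(O)c2c(oc(-c3ccc(F)c(C)c3)cc2=O)C(CC)(CC)C1=O`, has not yet been measured. It is reached from compound 2 by a single change:

fluoro in place of hydrogen on an aromatic carbon

Among the compounds with values here, no step between measured compounds of this kind is available, so the size of the effect cannot be read from the data. Within the data shown here, on the one change alone, a small step in this assay is expected, not beyond the scatter, in either direction. Compound 3 is therefore estimated at 3.2 uM, with a likely range of 1.3 uM to 8 uM, which means an expected step of a 1.2-fold lower number from compound 2 to compound 3 (0.06 log units; within the scatter).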

Compound 3, concentration for half-maximal effect: 1.62 uM
Compound 3: middle estimate off by 2.0-fold (0.30 log units), on the high side, within the range that was stated.
By their numbers in this assay, from the lowest: compound 3; then compound 2; then compound 1.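

In this assay, putting fluoro in place of hydrogen on the aromatic carbon ortho to the methyl group and para to the large group gives a 2.3-fold lower number from compound 2 to compound 3 (0.36 log units; beyond the scatter) and so moves the number down, not up. Within the data shown here, this is the first single-place change whose step can be read, and it shows that the aromatic carbon carrying this hydrogen is not indifferent to substitution: going from 3-methylphenyl to 4-fluoro-3-methylphenyl, a change of one heavy atom, is enough for a modest but real shift. Nothing measured here bears on what lies behind the step.

The compounds shown leave open whether the step belongs to fluoro itself, since chloro, methoxy or an amine on the same carbon could move the number to a similar degree, or in the other direction. They also leave open whether fluoro would give a step of this size without the neighbouring methyl group, as in a 4-fluorophenyl compound, so this single pair cannot yet be read as a general rule for the series.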